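From a methoxyphenyl to a nitrophenyl on the ring nitrogen

This account rests on a few compounds, and the source may have more. Where it says the series, first, only, none or still open, it means among the compounds named here.

For the measured compounds named here, in a functional assay on MCF7 cells (Homo sapiens) for cytotoxicity, read by MTT assay, with a stated time of 72 h (a higher number here means a weaker inhibitor, a lower number a stronger inhibitor), the values so far are these.
Compound 1 `CCCCCCNc1nc(SCc2ccc(C(F)(F)F)cc2)nc2ccccc12` gives 24300 nM.
Compound 2 `CCCCCCCCNc1nc(SCc2ccc(C(F)(F)F)cc2)nc2ccccc12` gives 26100 nM.
Compound 3 `COc1ccccc1Nc1nc(SCc2ccc(C(F)(F)F)cc2)nc2ccccc12` gives > 50000 nM, which is a limit of the assay rather than a number.

Compounds 1 and 2 differ only by a 1.1-fold higher number from compound 1 to compound 2 (0.03 log units; within the scatter). Compound 3 stands at the limit of > 50000 nM in this assay, at which 1 of the 3 values shown sits, so only a floor is known for it; the step of an at least 2.0-fold higher number from compound 1 to compound 3 (0.31 log units; beyond the scatter) and the step of an at least 1.9-fold higher number from compound 2 to compound 3 (0.28 log units; that floor lies within the scatter) both point toward a weaker inhibitor once an aryl group replaces a chain on that nitrogen. Compound 4 `O=[N+]([O-])c1cccc(Nc2nc(SCc3ccc(C(F)(F)F)cc3)nc3ccccc23)c1` keeps this arrangement, with 3-nitrophenyl in place of 2-methoxyphenyl on a nitrogen on an aromatic ring. Going by the values given here, no measured step compares two such aryl groups, so the floor for compound 3 is the nearest guide. The step that the limit leaves unreadable from compound 3 to compound 4 is therefore expected to be small, with the number likely to stay near or beyond the limit. Compound 4 is estimated at 55000 nM, with a range from 20000 nM to 150000 nM.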

Compound 4, half-maximal inhibitory concentration: > 50000 nM
Compound 4 ended at the assay's limit; the forecaster's own chance of this, stated with the estimate: 60%; the middle value does not contradict the limit.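

In this assay compound 4 gives > 50000 nM, which is a limit of the assay and not a number, as it is for compound 3. Against the chains this reads as an at least 2.0-fold higher number from compound 1 to compound 4 (0.31 log units; beyond the scatter) and an at least 1.9-fold higher number from compound 2 to compound 4 (0.28 log units; that floor lies within the scatter), so a second aryl group also falls on the weaker side, although only the floor against hexyl clears the scatter. The step between the two aryl groups cannot be read, so they cannot be ranked: the limit of > 50000 nM in this assay, at which 2 of the 4 values shown sit.

As far as these compounds go, whether any aryl group on this nitrogen can give a readable number stays open, for instance plain phenyl. The effect of a shorter chain such as butyl, or of a chain ending in an amine, is also unknown.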